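The compounds below may be only part of what the source reports. "The series", "measured", "known", "first", "only" and "open" are said of these compounds alone.

Of the compounds shown here, three sharing one core have been measured in a physicochemical assay for lipophilicity, read by HPLC, at pH 7.5; on this read-out higher numbers stand for higher lipophilicity and lower numbers for lower lipophilicity. Compound 1 `CCCCC(Nc1c(C#N)c(-c2ccc(-c3ccccc3OCC)cc2)nc2cnccc12)C(N)=O` gives 3.6. Compound 2 `CCOc1ccccc1-c1ccc(-c2nc3cnccc3c(C[C@H](C)C(=O)O)c2C#N)cc1` gives 2.2, the second highest of the three numbers; its nearest neighbour is compound 3 `CC(C)(CC(N)=O)c1c(C#N)c(-c2ccc(Br)cc2)nc2cnccc12`, which in this assay gives 2.1, a value within the scatter of compound 2, while compound 1 stands furthest from compound 2, beyond the scatter. Among the measured compounds shown here, the only step between measured compounds that differ in a single place is a number 1.40 log units lower from compound 1 to compound 2 (beyond the scatter), a large drop, in which a group of 6 heavy atoms with no ring replaces a group of 9 heavy atoms with no ring on an aromatic carbon.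

Compound 4 `CCOc1ccccc1-c1ccc(-c2nc3cnccc3c(N[C@H](CC(C)C)C(N)=O)c2C#N)cc1` has not yet been measured in this assay. It differs from compound 2 in one place: (1-carbamoyl-3-methylbutyl)amino in place of 2-carboxypropyl on an aromatic carbon. For the measured compounds named here, this exchange runs the other way round to the one seen between compound 1 and compound 2: a group of 9 heavy atoms, 6 carbon, 2 nitrogen and 1 oxygen, again takes the place of the 2-carboxypropyl group, the entering group of compound 4 being built of the same atoms as the one in compound 1. Because a number 1.40 log units lower from compound 1 to compound 2 (beyond the scatter) was large, a step of about the same size in the opposite direction is expected, namely a number 1.40 log units higher from compound 2 to compound 4 (beyond the scatter). Compound 4 is therefore estimated to give 3.6 in this assay, most likely between 3.2 and 4.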

Compound 4, distribution coefficient: 3.4
The estimate for compound 4 lay 0.20 log units above the measured number; the range from low to high includes it.
By their numbers in this assay, from the lowest: compounds 3 and 2 (each within the scatter of the next); then compounds 4 and 1 (each within the scatter of the next).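

In this assay, (1-carbamoyl-3-methylbutyl)amino in place of 2-carboxypropyl at this position, on an aromatic carbon ortho to a cyano group, gives a number 1.20 log units higher from compound 2 to compound 4 (beyond the scatter) and so shows that the large step seen with compound 1 is not tied to the 1-carbamoylpentyl chain alone. The chain on the nitrogen can also be exchanged, since 1-carbamoyl-3-methylbutyl in place of 1-carbamoylpentyl gives a number 0.20 log units lower from compound 1 to compound 4 (within the scatter) and leaves compound 1 and compound 4 together, each beyond the scatter from compound 2 on its printed step. No measurement shown here accounts for these numbers.

Since 2-carboxypropyl and the entering group differ at once in the atom joined to the ring, in chain length and in the carboxylic acid set against the primary amide, the compounds shown do not separate these features at this position. On these data alone, a carboxylic acid carried on the same nitrogen-linked chain, a simple amine or a longer chain at this position would each be a new case, and how any of them would read on this scale stays open.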